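The compounds below may be only part of what the source reports. "The series", "measured", "known", "first", "only" and "open" are said of these compounds alone.

Measured so far in this series:
compound 1 `CN(C)c1ccc(/C=C2\CNC/C(=C\c3ccc(N(C)C)cc3)C2=O)cc1` — 42500 nM
compound 2 `CCN(CC)c1ccc(/C=C2\CNC/C(=C\c3ccc(N(CC)CC)cc3)C2=O)cc1` — 35000 nM
compound 3 `CN1C/C(=C\c2ccc(N(C)C)cc2)C(=O)/C(=C/c2ccc(N(C)C)cc2)C1` — 28500 nM

All three values come from a functional assay on L1210 cells (Mus musculus) for inhibition, read by MTT assay, with a stated time of 72 h; on this read-out higher numbers stand for weaker inhibition and lower numbers for stronger inhibition. Compound 1 and compound 3 share one core and differ in a single place: methyl in place of hydrogen on an amine nitrogen in a ring. That change produced the step of a 1.5-fold lower number from compound 1 to compound 3 (0.17 log units; within the scatter), which stays inside the usual spread of repeat measurements. Compound 2 stands on a different core; how that core differs from the core of compound 1 is not broken down here, and its value lies close to those of compound 1 and compound 3, with all three numbers within the scatter of one another.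

Compound 4 `CCN(CC)c1ccc(/C=C2\CN(C)C/C(=C\c3ccc(N(CC)CC)cc3)C2=O)cc1` has not been measured yet. It differs from compound 2 by methyl in place of hydrogen on an amine nitrogen in a ring, which is the same change as from compound 1 to compound 3; the change occurs twice among these compounds, once measured and once open. For compound 4 in this assay the step of a 1.3-fold lower number from compound 2 to compound 4 (0.13 log units; within the scatter) is expected to be small, because the same change on the other core gave a 1.5-fold lower number from compound 1 to compound 3 (0.17 log units; within the scatter). Compound 4 is accordingly estimated at 26000 nM, with a likely range from 12000 nM to 60000 nM.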

Compound 4, half-maximal inhibitory concentration: 3300 nM
Compound 4: the middle estimate sits 7.9-fold (0.90 log units) above what was measured, outside the stated range (below it).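

In this assay, methyl in place of hydrogen on an amine nitrogen in a ring gives an 11-fold lower number from compound 2 to compound 4 (1.03 log units; beyond the scatter), so the size of this step does not carry over from one core to the other: the same change on two cores in this assay, a 1.5-fold lower number (0.17 log units; within the scatter) from compound 1 to compound 3 and an 11-fold lower number (1.03 log units; beyond the scatter) from compound 2 to compound 4, 7.1-fold (0.85 log units) apart, beyond the scatter of two such steps

The step on the core of compound 1 lies within the scatter and the step on the core of compound 2 lies beyond it, so a small step on one core did not predict a small step on the other. These two cores give a single comparison, which does not show what sets the steps apart and supports no rule for any further core.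

Open, as far as these compounds go, is whether a longer chain, such as ethyl or propyl, in place of methyl on the amine nitrogen in the ring would keep the value of compound 4 at 3300 nM. Also open, from the compounds shown here alone, is whether a morpholine in place of the diethylamino groups of compound 4 would leave a step of this size.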